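Swapping the Aryl Group: From Compound 1 to Compound 3

A few compounds are considered here, and "the series" means these few. Any claim that something is new, unique, unknown or untested is made for them only; others in the source may bear on it.

Compound 1 `COc1cccc(C(C2=C(O)C(=O)c3ccccc3C2=O)c2c[nH]c3ccccc23)c1` — 40000 nM
Compound 2 `O=C1C(O)=C(C(c2ccc([N+](=O)[O-])cc2)c2c[nH]c3ccc(Br)cc23)C(=O)c2ccccc21` — 16900 nM

Of the compounds shown here, two have been measured in a functional assay on ECa-109 cells (Homo sapiens) for cytotoxicity, read by MTT assay, with a stated time of 48 h; a lower number here means a stronger inhibitor, a higher number a weaker inhibitor. Compound 1 stands at the higher of the two numbers, giving 40000 nM, while compound 2 gives 16900 nM, a gap that lies beyond the usual scatter of the measurement. Compound 3 `O=C1C(O)=C(C(c2ccc(F)cc2)c2c[nH]c3ccccc23)C(=O)c2ccccc21` has not yet been measured. It differs from compound 1 in a single place: 4-fluorophenyl in place of 3-methoxyphenyl on a saturated chain carbon bound to an aromatic carbon and a double-bonded ring carbon. Within the data shown here, no pair of measured compounds reproduces this exchange, so nothing in the data fixes its size or direction. The account therefore expects only a small step from compound 1 to compound 3 in this assay, likely toward a somewhat lower number but possibly no change beyond the scatter, a 1.6-fold lower number from compound 1 to compound 3 (0.20 log units; within the scatter). Compound 3 is accordingly estimated at 25000 nM, with a range from 8000 nM to 80000 nM.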

Compound 3, half-maximal inhibitory concentration: 28100 nM
Beside the measured number, compound 3's estimate is 1.1-fold (0.05 log units) below it, and the stated range covers the measured number.
By their numbers in this assay, from the lowest: compounds 2, 3 and 1 (each within the scatter of the next, the first and the last beyond it).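

In this assay, among these compounds, the first exchange that can be read at this position, 4-fluorophenyl in place of 3-methoxyphenyl on a saturated chain carbon bound to an aromatic carbon and a double-bonded ring carbon, gives a 1.4-fold lower number from compound 1 to compound 3 (0.15 log units; within the scatter), so the two aryl groups cannot be told apart here. The exchange drops the single hydrogen-bond acceptor counted on the leaving group, and the number does not move beyond the scatter. Nothing measured in this set of compounds explains the outcome of this exchange.

Going by these compounds, the substituent and its place on the ring change together in this step, so the contribution of each remains open. Also open, on these data alone, is whether a phenyl carrying an amine or a carboxylic acid, or a longer chain on this carbon, would shift the number beyond the scatter.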